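The compounds below may be only part of what the source reports. "The series", "measured", "known", "first", "only" and "open" are said of these compounds alone.

Compound 1 `COC(=O)NC1CCc2ccc(NC(=O)c3cccc(C)c3-c3ccc(C(F)(F)F)cc3)cc2CC1` is the reference point of the series. In an assay on isolated protein for inhibition of microsomal triglyceride transfer protein large subunit (Homo sapiens) (on this read-out lower numbers stand for stronger inhibition and higher numbers for weaker inhibition), compound 1 gives 20 nM. Compound 2 `COC(=O)NC1CCc2ccc(NC(=O)c3cc(C)cc(C)c3-c3ccc(C(F)(F)F)cc3)cc2CC1` carries a methyl in place of hydrogen on an aromatic carbon, and in this assay compound 2 gives 20 nM; the step of no change at the digits printed from compound 1 to compound 2 (within the scatter) shows that this change leaves the read-out where it was. Among the compounds with values here, compound 1 thus stands level with compound 2, and no measured pair separates the two.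

Compound 3 `COC(=O)NC1CCc2ccc(NC(=O)c3cccc(C)c3-c3ccc(Cl)cc3)cc2CC1` is not yet measured. It differs from compound 1 by chloro in place of trifluoromethyl on an aromatic carbon. Within the data shown here, none of the measured steps touches this part of the molecule: the single step available, no change at the digits printed from compound 1 to compound 2 (within the scatter), concerns a methyl on a different aromatic carbon and offers no guide for the exchange at hand. Among the measured compounds shown here, with no precedent, the expectation for compound 3 rests on the reference alone and is framed broadly. Compound 3 is estimated at 30 nM in this assay, with a range of 10 nM to 100 nM. The step of a 1.5-fold higher number from compound 1 to compound 3 (0.18 log units; within the scatter) is expected to remain modest, the width of the range carrying the uncertainty.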

Compound 3, half-maximal inhibitory concentration: 80 nM
Estimate against measurement, compound 3: 2.7-fold (0.43 log units) below; the measured number falls inside the stated range.
By their numbers in this assay, from the lowest: compounds 1 and 2 (each within the scatter of the next); then compound 3.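

In this assay the exchange of 4-(trifluoromethyl)phenyl for 4-chlorophenyl gives a 4.0-fold higher number from compound 1 to compound 3 (0.60 log units; beyond the scatter) and so moves the read-out beyond the scatter, while the methyl step (no change at the digits printed from compound 1 to compound 2 (within the scatter)) leaves it in place. The position para to a large group therefore responds to what it carries, although modestly, and of the two groups compared there trifluoromethyl goes with the lower number and so with the stronger inhibition. Nothing on hand says what lies behind this step, whether the smaller count of heavy atoms or some other difference between the two groups.

The compounds shown hold only trifluoromethyl and chloro at this position, so it remains open where a nitrile, a methoxy group or plain hydrogen would fall relative to compound 1 and compound 3. Also open is whether the added methyl of compound 2 would leave the read-out unchanged alongside chloro, since the compounds shown pair that methyl only with trifluoromethyl.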